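Working notes: from 3-fluorophenyl to 2-chlorophenyl

The source may report more compounds than this note shows. Statements on the series, on what has been measured and on what is new or still open speak of the compounds shown alone.

Measured in an ADME assay on GES1 cells (Homo sapiens) for cytotoxicity, read by MTT assay, with a stated time of 24 h; on this read-out lower numbers stand for higher toxicity in this test and higher numbers for lower toxicity in this test:
- compound 1 `Cc1ccc(-n2cc(-c3ccccc3NS(=O)(=O)c3c[nH]c(=O)[nH]c3=O)nn2)cc1`: 32400 nM
- compound 2 `O=c1[nH]cc(S(=O)(=O)Nc2ccccc2-c2cn(-c3ccccc3F)nn2)c(=O)[nH]1`: > 100000 nM (a limit)
- compound 3 `O=c1[nH]cc(S(=O)(=O)Nc2ccccc2-c2cn(-c3cccc(F)c3)nn2)c(=O)[nH]1`: "not toxic" (no number reported)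

Compound 3 has no number in this assay and is reported only as "not toxic" (no number reported). Compound 2 gives > 100000 nM, which is a limit.

Compound 4 `O=c1[nH]cc(S(=O)(=O)Nc2ccccc2-c2cn(-c3ccccc3Cl)nn2)c(=O)[nH]1` carries 2-chlorophenyl in place of 3-fluorophenyl on an aromatic nitrogen.

Going by the values given here, the one measured step at this site is an at least 3.0-fold higher number from compound 1 to compound 2 (0.48 log units; beyond the scatter), with 2-fluorophenyl in place of 4-methylphenyl. It ends at the limit of > 100000 nM in this assay, at which 1 of the 3 values shown sits. It bears on the change only indirectly, as neither of its compounds carries chlorine and compound 3 offers no number to step from. Among the compounds with values here, compound 1 at 32400 nM is the only full number in the set. Within the data shown here, compound 4 is therefore expected to stay with the halogenated compounds, with no large step downward and perhaps only a limit reported.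

The estimated value for compound 4 is 85000 nM, with an expected range of 30000 nM to 150000 nM.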

Compound 4, half-maximal cytotoxic concentration: 20800 nM
For compound 4 the middle estimate is 4.1-fold (0.61 log units) above the measured one; the measured number lies below the stated range.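

In this assay, 2-chlorophenyl in place of 2-fluorophenyl gives an at least 4.8-fold lower number from compound 2 to compound 4 (0.68 log units; beyond the scatter), so the choice of halogen on this ring matters and a halogen alone does not keep the number high. Compound 2 stands at a limit, not a number: the limit of > 100000 nM in this assay, at which 1 of the 4 values shown sits. The other new comparison gives a 1.6-fold lower number from compound 1 to compound 4 (0.19 log units; within the scatter), which lies within the scatter, so 2-chlorophenyl and 4-methylphenyl cannot be told apart here, and the higher reading seen with 2-fluorophenyl does not extend to every halogenated ring.

Steps from compound 3 cannot be read: it is reported only as "not toxic", without a number, so the effect of the halogen's place on the ring stays open. Also open, on these data alone, is how 2-bromophenyl or 2-methoxyphenyl would read at this position.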